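The source may hold more compounds than are shown below. What is called first, only, known or untested is meant among the compounds shown, and "the series" means these compounds.

Measured compounds:
- compound 1, `COc1c(F)cccc1C1CCN(c2ccn3c(CC(F)(F)F)nnc3c2C#N)CC1`: 0.047
- compound 2, `COc1ccc(F)cc1C1CCN(c2ccn3c(CC(F)(F)F)nnc3c2Cl)CC1`: < 0.01
- compound 3, `COc1ccccc1C1CCN(c2ccn3c(CC4CC4)nnc3c2Cl)CC1`: < 0.01

In an ADME assay on a cell-free system (plasma, Homo sapiens) for protein binding (a higher number here means a larger unbound share of the compound, a lower number a smaller unbound share), compound 1 gives 0.047. For compound 2 the result in this assay is a limit of the assay rather than a number, < 0.01. For compound 3 the result in this assay is likewise only a limit, < 0.01. Compound 3 therefore cannot be placed against compound 2 on the numbers, and both sit at the limit of < 0.01 in this assay, at which 2 of the 3 values shown sit; only compound 1 returned a measurable unbound fraction.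

The next compound, compound 4, has the structure `COc1ccc(F)cc1C1CCN(c2ccn3c(CC4CC4)nnc3c2Cl)CC1`. It differs from compound 3 in one place: fluoro in place of hydrogen on an aromatic carbon. Compound 2 carries the same 5-fluoro-2-methoxyphenyl group and is itself at the limit in this assay.

With compound 3 already at the limit, no upward movement is expected from this change, and the step from compound 3 to compound 4 is estimated at a step that the limit leaves unreadable from compound 3 to compound 4, which is within the scatter in either direction. Compound 4 is expected to give 0.006 in this assay, with a range from 0.002 to 0.012, and most likely to be reported again only as a limit.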

Compound 4, unbound fraction: < 0.01
Compound 4: only a limit was reported; the forecaster's own chance of this, stated with the estimate: 80%; the middle value is on the limit's open side.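

In this assay, compound 4 gives < 0.01, which is a limit of the assay and not a number. Neither the step from compound 3 to compound 4 nor the step from compound 2 to compound 4 can be read: the limit of < 0.01 in this assay, at which 3 of the 4 values shown sit. The compounds shown leave open how fluoro in place of hydrogen, or cyclopropyl in place of trifluoromethyl, shifts the unbound fraction.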